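This account rests on a few compounds, and the source may have more. Where it says the series, first, only, none or still open, it means among the compounds named here.

Compound 1 `COc1ccccc1-c1ncnn1-c1cc(OC)c(OC)c(OC)c1` and compound 2 `COc1cc(-c2ncnn2-c2cccc(N)c2)cc(OC)c1OC` share one core and carry the same two aryl groups in exchanged places. In a functional assay on MCF7 cells (Homo sapiens) for antiproliferative activity, read by MTT assay, with a stated time of 72 h (a higher number here means a weaker inhibitor, a lower number a stronger inhibitor), compound 1 reports only a limit, > 10000 nM. In this assay compound 2 likewise reports only a limit, > 10000 nM. Compound 2 therefore stands at the limit of > 10000 nM in this assay, at which 2 of the 2 values shown sit. Compound 3 `COc1ccc(-n2ncnc2-c2cc(OC)c(OC)c(OC)c2)cc1` differs from compound 2 by 4-methoxyphenyl in place of 3-aminophenyl on an aromatic nitrogen. Among the compounds with values here, no step between measured compounds is available; the expected step of an at least 1.2-fold lower number from compound 2 to compound 3 (0.09 log units; that floor lies within the scatter) is accordingly uncertain, and no change beyond the scatter is assumed. Compound 3 is expected to give 8000 nM in this assay, with a range from 1000 nM to 30000 nM, most likely again reported as a limit.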

Compound 3, half-maximal inhibitory concentration: 7400 nM
Beside the measured number, compound 3's estimate is 1.1-fold (0.03 log units) above it, and the stated range covers the measured number.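

In this assay, within the data shown here, 4-methoxyphenyl in place of 3-aminophenyl on an aromatic nitrogen gives the first value that is a number and not a limit, with an at least 1.3-fold lower number from compound 2 to compound 3 (0.13 log units; that floor lies within the scatter). Only a floor can be read for this step, and its full size stays unknown, since compound 2 gives a limit: the limit of > 10000 nM in this assay, at which 2 of the 3 values shown sit.

The compounds shown do not separate the gain of the methoxy group from the loss of the amine. Going by these compounds, how a 4-hydroxyphenyl or 4-chlorophenyl group would read on this nitrogen remains open.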